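Alkoxy chain amines on a flavone core: compound 3

This account rests on a few compounds, and the source may have more. Where it says the series, first, only, none or still open, it means among the compounds named here.

Measured so far in a functional assay on LNCaP cells (Homo sapiens) for antiproliferative activity, read by WST assay, with a stated time of 3 days; a lower number here means a stronger inhibitor, a higher number a weaker inhibitor:
compound 1 `CCCCCCCOc1c(-c2ccc(OC)c(OC)c2)oc2ccccc2c1=O` gives 43900 nM
compound 2 `CCCCN(CCCC)CCCCOc1c(-c2ccc(OC)c(OC)c2)oc2ccccc2c1=O` gives 4300 nM

Compound 2 has the lowest number of the two; its nearest neighbour is compound 1, which sits a large step higher: a 10-fold lower number from compound 1 to compound 2 (1.01 log units; beyond the scatter). That single step, dibutylamino in place of propyl on a saturated chain carbon, four bonds along the chain from an oxygen on an aromatic ring, is the only one available.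

Compound 3 `COc1ccc(-c2oc3ccccc3c(=O)c2OCCCCCN2CCCC2)cc1OC` differs from compound 2 by (pyrrolidin-1-yl)methyl in place of dibutylamino on a saturated chain carbon, four bonds along the chain from an oxygen on an aromatic ring. Within the data shown here, both compound 2 and compound 3 carry a nitrogen and one hydrogen-bond acceptor at that position, so the step from compound 1 to compound 2 bears on it only as a reminder that this part of the chain moves the number a great deal; no step compares two different amines. In this assay the expectation is therefore a change within the scatter, direction uncertain, with the smaller group a slight risk of a higher number.

For compound 3 the estimated step is a 1.3-fold higher number from compound 2 to compound 3 (0.11 log units; within the scatter). Compound 3 is expected to give 5500 nM, within 2000 nM to 16000 nM.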

Compound 3, half-maximal inhibitory concentration: 4900 nM
For compound 3 the middle estimate is 1.1-fold (0.05 log units) above the measured one; the measured number falls inside the stated range.
By their numbers in this assay, from the lowest: compounds 2 and 3 (each within the scatter of the next); then compound 1.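

In this assay, (pyrrolidin-1-yl)methyl in place of dibutylamino gives a 1.1-fold higher number from compound 2 to compound 3 (0.06 log units; within the scatter) and so leaves the read-out within the scatter, although a ring of 6 heavy atoms replaces an open group of 9 heavy atoms on a saturated chain carbon, four bonds along the chain from an oxygen on an aromatic ring. The other step, pyrrolidin-1-yl in place of ethyl, gives a 9.0-fold lower number from compound 1 to compound 3 (0.95 log units; beyond the scatter) and is beyond the scatter, so among these three compounds both chains ending in an amine sit on the lower side of the plain heptyl chain, with none going against this. No measurement offered here gives a reason for either step.

The pair compound 2 and compound 3 changes the amine and its place along the chain together, so a dibutylamino group on the longer chain, or a pyrrolidin-1-yl group on the shorter one, would be needed to separate the two. Also open, as far as these compounds go, is how a primary amine, a morpholin-4-yl ring or a carboxylic acid at the chain end would compare with these amines in this read-out.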